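Replacing dimethylamino with methoxy on the shared core

This account rests on a few compounds, and the source may have more. Where it says the series, first, only, none or still open, it means among the compounds named here.

Measured in a functional assay on HSC-4 cells (Homo sapiens) for cytotoxicity, with a stated time of 24 h; a higher number here means that more compound is tolerated, a lower number that less compound is tolerated:
compound 1 `O=C1/C(=C/c2ccccc2)CCC/C1=C\c1ccccc1[N+](=O)[O-]`: 3200 nM
compound 2 `O=C1/C(=C/c2ccc(Cl)cc2)CCC/C1=C\c1ccccc1[N+](=O)[O-]`: 6100 nM
compound 3 `CN(C)c1ccc(/C=C2\CCC/C(=C\c3ccccc3[N+](=O)[O-])C2=O)cc1`: > 400000 nM

Compound 3 stands at > 400000 nM in this assay, which is a limit of the assay and not a number.

The next structure, compound 4 `COc1ccc(/C=C2\CCC/C(=C\c3ccccc3[N+](=O)[O-])C2=O)cc1`, has methoxy in place of dimethylamino on an aromatic carbon, para to a large group (methoxy in place of dimethylamino on an aromatic carbon). Going by the values given here, the change removes the one group that sets compound 3 apart from the other two measured compounds.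

Among the compounds with values here, three measured steps bear on it. Dimethylamino in place of hydrogen gave an at least 120-fold higher number from compound 1 to compound 3 (2.09 log units; beyond the scatter), and dimethylamino in place of chloro gave an at least 65-fold higher number from compound 2 to compound 3 (1.81 log units; beyond the scatter). On these data alone, both are large, and both end at a limit, so their true size stays open. Chloro in place of hydrogen gave only a 1.9-fold higher number from compound 1 to compound 2 (0.28 log units; within the scatter).

Compound 4 has lost the dimethylamino group, so it is expected to fall back towards the measured numbers of the other two compounds. Within the data shown here, no methoxy compound has been measured here, which keeps the range wide. The expected change is a large one towards a lower number, an at least 44-fold lower number from compound 3 to compound 4 (1.64 log units; beyond the scatter). For compound 4 the estimated value is 9000 nM, with an expected range of 2500 nM to 60000 nM.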

Compound 4, half-maximal cytotoxic concentration: 24000 nM
The estimate for compound 4 lay 2.7-fold (0.43 log units) below the measured number, within the range that was stated.
By their numbers in this assay, from the lowest: compounds 1 and 2 (each within the scatter of the next); then compound 4. At a limit, above all of these: compound 3.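

Methoxy on this aromatic carbon, para to a large group, is the first replacement for dimethylamino shown that keeps an oxygen or nitrogen substituent at this position, and in this assay it gives an at least 16-fold lower number from compound 3 to compound 4 (1.22 log units; beyond the scatter). The position also does more than separate dimethylamino from everything else, since methoxy stands apart from the two smaller substituents as well, with a 3.9-fold higher number from compound 2 to compound 4 (0.59 log units; beyond the scatter) and a 7.5-fold higher number from compound 1 to compound 4 (0.88 log units; beyond the scatter), both beyond the scatter, whereas chloro and hydrogen had stayed within the scatter of each other. The full size of the step away from dimethylamino stays open because compound 3 has only a limit of the assay and not a number:  the limit of > 400000 nM in this assay, at which 1 of the 4 values shown sits.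

With only hydrogen, chloro, methoxy and dimethylamino at this position, the compounds shown do not tell whether another amine, such as a cyclic amine, would follow dimethylamino, or whether a longer ether chain would stay close to methoxy. A hydroxyl group or a carboxylic acid in the same place also remains an open case, as does whether this order of groups would hold on any other cells.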